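Methoxy position on the phenyl ring and inhibition

A few compounds are considered here, and "the series" means these few. Any claim that something is new, unique, unknown or untested is made for them only; others in the source may bear on it.

Measured in an assay on isolated protein for inhibition of Amine oxidase [flavin-containing] B (Homo sapiens); a higher number here means a weaker inhibitor, a lower number a stronger inhibitor:
Compound 1 `C#CCNC1CCc2c(SCCc3ccc(C)cc3)cccc21` gives 25800 nM.
Compound 2 `C#CCNC1CCc2c(SCCc3cccc(Br)c3)cccc21` gives 30500 nM.
Compound 3 `C#CCNC1CCc2c(SCCc3cccc(OC)c3)cccc21` gives 28700 nM.

Among these three numbers compound 3 holds the second highest, with compound 2 nearest and compound 1 furthest, and neither gap reaches beyond the usual scatter: a 1.1-fold lower number from compound 2 to compound 3 (0.03 log units; within the scatter), and a 1.1-fold higher number from compound 1 to compound 3 (0.05 log units; within the scatter). Compound 4 `C#CCNC1CCc2c(SCCc3ccc(OC)cc3)cccc21` is not yet measured in this assay; it differs from compound 3 by 4-methoxyphenyl in place of 3-methoxyphenyl on a saturated chain carbon, two bonds along the chain from a sulfur. Going by the values given here, the steps that bear on this change are those that alter the group on the phenyl ring or its position: a 1.2-fold higher number from compound 1 to compound 2 (0.07 log units; within the scatter), a 1.1-fold higher number from compound 1 to compound 3 (0.05 log units; within the scatter) and a 1.1-fold lower number from compound 2 to compound 3 (0.03 log units; within the scatter). All three are within the scatter, so the three measured compounds give no sign that either the identity or the placement of the substituent on the phenyl ring shifts the number in this assay. The step from compound 3 to compound 4 is therefore expected to be a 1.0-fold lower number from compound 3 to compound 4 (0.01 log units; within the scatter), with no direction beyond the scatter. Compound 4 is estimated at 28000 nM, with a range from 14000 nM to 56000 nM.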

Compound 4, half-maximal inhibitory concentration: 62000 nM
For compound 4 the middle estimate is 2.2-fold (0.35 log units) below the measured one; measured number outside the range, above it.
By their numbers in this assay, from the lowest: compounds 1, 3 and 2 (each within the scatter of the next); then compound 4.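

In this assay, going by these compounds alone, moving the methoxy group changes the number beyond the scatter (a 2.2-fold higher number from compound 3 to compound 4 (0.33 log units; beyond the scatter)), so the placement of this group on the phenyl ring matters, which the earlier compounds gave no sign of. Placement alone does not account for the shift, as compound 1 also carries a 4-substituted phenyl ring yet lies within the scatter of compound 2 and compound 3, whereas methoxy in place of methyl gives a step beyond it (a 2.4-fold higher number from compound 1 to compound 4 (0.38 log units; beyond the scatter)); compound 4 also stands apart from the 3-bromophenyl compound (a 2.0-fold higher number from compound 2 to compound 4 (0.31 log units; beyond the scatter)). Nothing available gives a reason for this shift.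

On these data alone, it remains open whether the shift is particular to methoxy or would also appear with ethoxy, hydroxy or an amine in the same place. As far as these compounds go, the effect of a longer chain between the sulfur and the phenyl ring also remains open.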